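The compounds below may be only part of what the source reports. "The series", "measured", "known", "first", "only" and "open" are said of these compounds alone.

Compound 1 `O=C1Nc2c(ccc(F)c2F)C1(c1ccc(O)cc1)c1ccc(F)cc1` and compound 3 `COc1ccc2c(c1C)NC(=O)C2(c1ccc(O)cc1)c1ccc(F)cc1` both carry a 4-hydroxyphenyl group and a 4-fluorophenyl group on the same saturated ring carbon of a fused two-ring core, but the two cores themselves are substituted differently; the difference between the two cores is not broken down here. In a functional assay on PC-3 cells (Homo sapiens) for cytotoxicity, read by WST assay, with a stated time of 72 h (a lower number here means a stronger inhibitor, a higher number a weaker inhibitor), compound 1 gives 8.6 nM. In this assay compound 3 gives 9 nM. These two values lie within the usual scatter of each other, so no order can be read from them.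

Compound 2 `O=C1Nc2c(ccc(F)c2F)C1(c1ccc(O)cc1)C1CCCC1` arises from compound 1 by a single change: cyclopentyl in place of 4-fluorophenyl on a saturated ring carbon. In this assay compound 2 gives 8.2 nM, which is a step of a 1.0-fold lower number from compound 1 to compound 2 (0.02 log units; within the scatter). The values of compound 2 and compound 3 also lie within the scatter of each other.

Compound 4 `COc1ccc2c(c1C)NC(=O)C2(c1ccc(O)cc1)C1CCCC1` has not yet been measured. It arises from compound 3 by the same change, at a place described in identical words: cyclopentyl in place of 4-fluorophenyl on a saturated ring carbon. Going by the values given here, the one measured example of this change is the step of a 1.0-fold lower number from compound 1 to compound 2 (0.02 log units; within the scatter), which stays within the scatter, and on that rests the expectation that swapping the same groups on the core of compound 3 will again move the number very little. Compound 4 is therefore expected to show a step of a 1.1-fold lower number from compound 3 to compound 4 (0.02 log units; within the scatter). Compound 4 is estimated at 8.5 nM in this assay, with a likely range from 4 nM to 18 nM.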

Compound 4, half-maximal inhibitory concentration: 111 nM
For compound 4 the middle estimate is 13-fold (1.12 log units) below the measured one; the measured number lies above the stated range.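

Carrying the swap of 4-fluorophenyl for cyclopentyl over to a new core did not give the same result in this assay; on the core of compound 3 the step is a 12-fold higher number from compound 3 to compound 4 (1.09 log units; beyond the scatter). Going by these compounds alone, the effect of this change therefore depends on the core that carries it, and a step measured on one core was a poor guide to the step on the other: the same change on two cores in this assay, a 1.0-fold lower number (0.02 log units; within the scatter) from compound 1 to compound 2 and a 12-fold higher number (1.09 log units; beyond the scatter) from compound 3 to compound 4, 13-fold (1.11 log units) apart, beyond the scatter of two such steps The cores of compound 1 and compound 3 are substituted differently, but these two steps do not show which of those substituents matters or how it alters the effect of the change, and with only two cores they give no rule for a third.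

The compounds shown leave open how the cyclopentyl change would behave on a core carrying only the methoxy group or only the methyl group of compound 3, which would help to locate the source of the difference. They also leave open how other groups on the same saturated ring carbon, such as a longer chain or an amine, would fare on each of the two cores.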